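Tolerated concentrations: the step to compound 3

The source may hold more compounds than are shown below. What is called first, only, known or untested is meant among the compounds shown, and "the series" means these compounds.

Measured so far in a toxicity assay on Vero C1008 cells (Chlorocebus sabaeus) for cytotoxicity, read by MTT assay, with a stated time of 48 h; a higher number here means that more compound is tolerated, a lower number that less compound is tolerated
Compound 1 `O=C(Nc1cccc(Cl)c1)c1cc(Cl)ccc1O` gives 2460 nM
Compound 2 `Cc1ccc(O)c(C(=O)Nc2ccc([N+](=O)[O-])cc2Cl)c1` gives 5680 nM

Compound 2 holds the higher of the two numbers, and compound 1 lies lower by a margin beyond the scatter. Compound 3 `O=C(Nc1ccc([N+](=O)[O-])cc1Cl)c1cc(F)ccc1O` has yet to be measured. It differs from compound 2 (fluoro in place of methyl on an aromatic carbon) by fluoro in place of methyl on an aromatic carbon, para to a hydroxy group. For the measured compounds named here, no pair of measured compounds differs in one place only, so this assay offers no direct guide to this change. With only compound 1 at 2460 nM and compound 2 at 5680 nM to go on, the range has to stay wide. The estimated 1.4-fold lower number from compound 2 to compound 3 (0.15 log units; within the scatter) is expected to be modest, towards a lower number, and to stay within the scatter. Compound 3 is estimated at 4000 nM with 1600 nM to 10000 nM as the expected range.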

Compound 3, half-maximal cytotoxic concentration: 8150 nM
Estimate against measurement, compound 3: 2.0-fold (0.31 log units) below; measured number inside the range.
By their numbers in this assay, from the lowest: compound 1; then compounds 2 and 3 (each within the scatter of the next).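

In this assay the exchange of methyl for fluoro on an aromatic carbon, para to a hydroxy group, gives a 1.4-fold higher number from compound 2 to compound 3 (0.16 log units; within the scatter) and so leaves the two groups indistinguishable at this position in this read-out. For the compounds shown here, this is the first comparison that differs in one place only, but as a single pair it describes this exchange on this core and supports no wider trend. No measurement is available that bears on why compound 2 and compound 3 read alike.

From the compounds shown here alone, whether an amine, a carboxylic acid or a longer chain at this position would also stay within the scatter of compound 2 remains open. Also open, going by these compounds, is whether fluoro in place of methyl would read the same way on a different core.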